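Aryl directly on the ring replaces a propyl tether

This account rests on a few compounds, and the source may have more. Where it says the series, first, only, none or still open, it means among the compounds named here.

Compound 1 `Nc1nc(N2CCN(C(=O)COc3ccc(Cl)cc3)CC2)c2nc(CCOc3ccc(F)cc3)sc2n1` gives 3540 nM in a functional assay on cells (Lymphocyte, Homo sapiens); on this read-out higher numbers stand for weaker inhibition and lower numbers for stronger inhibition.
Compound 2 `COc1ccc(OCC(=O)N2CCN(c3nc(N)nc4sc(-c5ccc(F)cc5)nc34)CC2)cc1` gives 40 nM in this assay.
Compound 3 `Nc1nc(N2CCN(C(=O)COc3ccc(Cl)cc3)CC2)c2nc(CCCc3ccc(F)cc3)sc2n1` gives 960 nM in this assay.

Compound 3 holds the second highest of the three numbers; compound 1 sits closest, while compound 2 lies furthest, with a much lower number. Going by the values given here, the one measured step, a 3.7-fold lower number from compound 1 to compound 3 (0.57 log units; beyond the scatter), concerns the tether and not the change now examined. Compound 4 `Nc1nc(N2CCN(C(=O)COc3ccc(Cl)cc3)CC2)c2nc(-c3ccc(Cl)cc3)sc2n1` differs from compound 3 by 4-chlorophenyl in place of 3-(4-fluorophenyl)propyl on an aromatic carbon. Among the compounds with values here, no measured step covers this change; the values of compound 2 and compound 3 only show that an aryl carried directly on that carbon coincides with the lowest number here. Compound 4 is therefore expected to give a markedly lower number, a 14-fold lower number from compound 3 to compound 4 (1.14 log units; beyond the scatter), estimated at 70 nM with a range from 15 nM to 350 nM.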

Compound 4, half-maximal inhibitory concentration: 270 nM
The estimate for compound 4 lay 3.9-fold (0.59 log units) below the measured number; low and high end bracket the measured number.
By their numbers in this assay, from the lowest: compound 2; then compound 4; then compound 3; then compound 1.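

In this assay, 4-chlorophenyl on this aromatic carbon gives a 3.6-fold lower number from compound 3 to compound 4 (0.55 log units; beyond the scatter) when it replaces 3-(4-fluorophenyl)propyl and a 13-fold lower number from compound 1 to compound 4 (1.12 log units; beyond the scatter) when it replaces 2-(4-fluorophenoxy)ethyl. Among these three compounds, which differ only at this carbon, the aryl carried directly on the ring therefore gives the lowest number, and the step from the ether chain is the larger of the two. Nothing at hand explains these steps.

Going by these compounds, it remains open how a plain phenyl, a pyridine ring or a methyl group would read at this carbon. Compound 2 differs from compound 4 in more than one place, so the separate contributions of those changes remain unresolved.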